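Methoxyphenyl Analogue of the Chlorobenzyl Thiadiazole Amide

The source may report more compounds than this note shows. Statements on the series, on what has been measured and on what is new or still open speak of the compounds shown alone.

Of the compounds shown here, three have been measured in a functional assay on HeLa cells (Homo sapiens) for inhibition, read by cell counting, with a stated time of 4 days; on this read-out higher numbers stand for weaker inhibition and lower numbers for stronger inhibition. Compound 1 `C=C(Br)C(=O)Nc1cccc(-c2cn3nc(-c4ccc(OCC)cc4)sc3n2)c1` gives 1100 nM. Compound 2 `C=C(Br)C(=O)Nc1cccc(-c2cn3nc(Cc4ccc(Cl)cc4)sc3n2)c1` gives 2700 nM and stands second highest of the three numbers, with compound 3 `Nc1cccc(-c2cn3nc(Cc4ccc(Cl)cc4)sc3n2)c1` at 25000 nM furthest from it. The change a 9.3-fold higher number from compound 2 to compound 3 (0.97 log units; beyond the scatter) removed the acrylamide group; the change a 2.5-fold higher number from compound 1 to compound 2 (0.39 log units; beyond the scatter) swapped the aryl substituent on the shared core. Compound 4 `C=C(Br)C(=O)Nc1cccc(-c2cn3nc(-c4ccc(OC)cc4)sc3n2)c1` carries the change (4-methoxyphenyl in place of 4-chlorobenzyl on an aromatic carbon). This reverses the sense of the step from compound 1 to compound 2, and a methoxy differs from an ethoxy only by one carbon, so a step of similar size in the opposite direction is expected in this assay. The expected step is a 2.5-fold lower number from compound 2 to compound 4 (0.39 log units; beyond the scatter). Compound 4 is therefore estimated at 1100 nM, within 400 nM to 3000 nM.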

Compound 4, half-maximal inhibitory concentration: 2300 nM
The estimate for compound 4 lay 2.1-fold (0.32 log units) below the measured number, within the range that was stated.
By their numbers in this assay, from the lowest: compound 1; then compounds 4 and 2 (each within the scatter of the next); then compound 3.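

In this assay, 4-methoxyphenyl and 4-chlorobenzyl on this aromatic carbon cannot be told apart (a 1.2-fold lower number from compound 2 to compound 4 (0.07 log units; within the scatter)). The smaller change within the alkoxy group, hydrogen in place of methyl, is readable (a 2.1-fold higher number from compound 1 to compound 4 (0.32 log units; beyond the scatter)), so the difference between compound 1 and compound 2 does not follow from replacing the aryl group with a benzyl group alone. No available evidence explains either step.

As far as these compounds go, whether a longer chain such as propoxy, or an amine on that phenyl ring, would shift the number remains open. Also open, from the compounds shown here alone, is what removing the (1-bromoethenyl)carbonyl group does in the 4-methoxyphenyl compound.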